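The source may report more compounds than this note shows. Statements on the series, on what has been measured and on what is new or still open speak of the compounds shown alone.

Of the compounds shown here, two built on a shared core have been measured so far. Compound 1 `COc1cc(/C=C/C(=O)C2=C(/C=C/c3ccc(O)c(OC)c3)NC(=O)NC2c2ccccc2)ccc1O` and compound 2 `COc1cc(/C=C/C(=O)C2=C(/C=C/c3ccc(O)c(OC)c3)NC(=S)NC2c2ccc(C)cc2)ccc1O` were each tested in a functional assay, with a stated time of 20 min, tested at 10 uM; a higher number here means a stronger effect of the compound at the concentration tested, a lower number a weaker effect. In this assay compound 1 gives 26.4%, while compound 2 gives 43.2%. Compound 2 thus stands highest of the two numbers, and its nearest neighbour, compound 1, lies below it by a gap that exceeds the usual scatter. Compound 3 `COc1cc(/C=C/C(=O)C2=C(/C=C/c3ccc(O)c(OC)c3)NC(=S)NC2c2ccccc2Cl)ccc1O` has not yet been measured. It differs from compound 2 in one place: 2-chlorophenyl in place of 4-methylphenyl on a saturated ring carbon. Going by the values given here, no step between measured compounds that differ in a single place is available to show how such an exchange acts, so the expectation rests on compound 2 alone. The step of a number 5.2 percentage points lower from compound 2 to compound 3 (within the scatter) is expected to be small, in either direction or none beyond the scatter. Compound 3 is therefore estimated at 38% in this assay, with a range from 22% to 55%.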

Compound 3, a percentage reported as activity, at one concentration (the size of the read-out at that concentration, not a potency): 43.2%
For compound 3 the middle estimate is 5.2 percentage points below the measured one, and the stated range covers the measured number.
By their numbers in this assay, from the lowest: compound 1; then compounds 2 and 3 (each within the scatter of the next).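

In this assay, putting 2-chlorophenyl in place of 4-methylphenyl on the saturated ring carbon gives no change at the digits printed from compound 2 to compound 3 (within the scatter) at the single concentration tested. Going by these compounds alone, this is the first step in the set that changes only one place, and it shows that at this position, one substituted phenyl group can replace the other without moving the read-out beyond the scatter. No measurement here bears on why these two groups read alike.

Within the data shown here, only this one exchange has been seen at this position, so it remains open whether a group without a phenyl ring, such as an amine, a carboxylic acid or a longer alkyl chain, would leave the read-out just as unmoved. Because the read-out comes from one concentration, the compounds also leave open whether their potencies match.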